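Imidazole for Triazole at the Aryl Position

This account rests on a few compounds, and the source may have more. Where it says the series, first, only, none or still open, it means among the compounds named here.

Compound 1 `CCn1ncnc1-c1ccccc1NCC1=NCCN1`: 94%
Compound 2 `Cn1ncnc1-c1ccccc1NCC1=NCCN1`: 93%

Going by the values given here, in a functional assay with Alpha-1B adrenergic receptor (Homo sapiens) as the target, read by calcium flux (on this read-out lower numbers stand for smaller maximal responses and higher numbers for larger maximal responses), compound 2 stands close to its only neighbour: the gap a number 1 percentage points lower from compound 1 to compound 2 (within the scatter) lies within the scatter. Compound 3 `Cn1ccnc1-c1ccccc1NCC1=NCCN1` is not yet measured. It differs from compound 2 by 1-methyl-1H-imidazol-2-yl in place of 1-methyl-1H-1,2,4-triazol-5-yl on an aromatic carbon. Among the compounds with values here, the single measured step, a number 1 percentage points lower from compound 1 to compound 2 (within the scatter), concerns a different position and does not bear on this exchange, so no measured step informs it. With nothing pointing either way, the step is expected to be a number 3 percentage points lower from compound 2 to compound 3 (within the scatter), none beyond the scatter. Compound 3 is therefore estimated at 90%, between 72% and 102%.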

Compound 3, largest response reached (reported as maximal response), in percent of the reference or control that the assay uses: 104%
For compound 3 the middle estimate is 14 percentage points below the measured one; the whole stated range lies below it.
By their numbers in this assay, from the lowest: compounds 2, 1 and 3 (each within the scatter of the next, the first and the last beyond it).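

In this assay, going by these compounds alone, the group on the aromatic carbon matters: 1-methyl-1H-imidazol-2-yl in place of 1-methyl-1H-1,2,4-triazol-5-yl gives a number 11 percentage points higher from compound 2 to compound 3 (beyond the scatter) while the only earlier step, a number 1 percentage points lower from compound 1 to compound 2 (within the scatter) at the chain on the aromatic nitrogen, showed no change. Exchanging one five-membered aromatic ring for another of equal heavy-atom count, with one hetero atom fewer, is thus enough to shift the maximal response. Nothing available explains this shift.

Going by these compounds, whether a phenyl or a 1-methyl-1H-pyrazol-5-yl group at this carbon would keep the higher response remains open. So does whether an ethyl group on the imidazole nitrogen would leave it unchanged.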